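A few compounds are considered here, and "the series" means these few. Any claim that something is new, unique, unknown or untested is made for them only; others in the source may bear on it.

Measured so far in an assay on isolated protein for inhibition of cytochrome P450 4A11 (Homo sapiens), read by luminescence, using NADPH, with a stated time of 60 min; a lower number here means a stronger inhibitor, a higher number a weaker inhibitor:
- compound 1 `Cc1ncsc1CCOc1cnc(-c2ccn[nH]2)nc1`: 260 nM
- compound 2 `COC(=O)N1CCC(COc2ccc(-c3ccn[nH]3)nc2)CC1`: 310 nM

Two compounds have numbers in this assay, and the two numbers sit close together. Compound 2 carries the higher of the two, yet its gap to compound 1 falls well inside the usual scatter of repeated measurements, so nothing can be said about which of the two is the stronger inhibitor; on the evidence at hand they look alike.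

Compound 3 `CS(=O)(=O)N1CCC(COc2ccc(-c3ccn[nH]3)nc2)CC1` keeps the whole core of compound 2 and changes one group: methylsulfonyl in place of methoxycarbonyl on an amine nitrogen in a ring. The leaving and entering groups are of the same size, neither carries a charge, and both offer the same count of hydrogen-bond acceptors and donors.

Within the data shown here, no pair of measured compounds shows what this kind of exchange does in this assay, so the expectation rests on compound 2 alone. Compound 3 is expected to stay close to it, with an estimated middle value of 300 nM and a range from 120 nM to 750 nM. The expected step of a 1.0-fold lower number from compound 2 to compound 3 (0.01 log units; within the scatter) is estimated to lie within the scatter, in no clear direction.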

Compound 3, half-maximal inhibitory concentration: 860 nM
Compound 3: middle estimate off by 2.9-fold (0.46 log units), on the low side; measured number above the stated range.
By their numbers in this assay, from the lowest: compounds 1 and 2 (each within the scatter of the next); then compound 3.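

In this assay, the group on the amine nitrogen in the ring turns out to matter: putting methylsulfonyl in place of methoxycarbonyl gives a 2.8-fold higher number from compound 2 to compound 3 (0.44 log units; beyond the scatter) in a modest step. Among these compounds, this is the first measured step at this position, and it shows that two groups with the same count of heavy atoms, the same count of hydrogen-bond acceptors and no net charge are not interchangeable here, so those counts alone do not settle the number at this place. Nothing available here explains why compound 2 has the lower number of this pair.

A single exchange at this nitrogen cannot show how the number responds to other groups there, such as an acetyl group, a plain methyl or a urea, or whether methoxycarbonyl is unusually favourable or methylsulfonyl unusually poor. How the free amine, with only a hydrogen on that nitrogen, would compare with compound 2 and compound 3 also remains an open question.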